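The source may hold more compounds than are shown below. What is called first, only, known or untested is meant among the compounds shown, and "the series" means these compounds.

In an ADME assay on NIH3T3 cells (Mus musculus) for cytotoxicity, read by neutral red uptake, with a stated time of 24 h (a higher number here means that more compound is tolerated, a lower number that less compound is tolerated), compound 1 (`Clc1ccc(-c2ccc(CNCC3CCNCC3)o2)c(Br)c1`) gives < 5 uM. That reading is a limit of the assay and not a number, so compound 1 has no exact place on the scale. Among the measured compounds shown here, compound 2 (`Clc1cc(-c2ccccc2)ccc1-c1ccc(CNCC2CCNCC2)o1`) gives 5 uM, the only exact number so far in this assay.

Compound 3 (`Clc1ccc(-c2ccc(CNCC3CCNCC3)o2)c(-c2ccccc2)c1`) carries phenyl in place of bromo on an aromatic carbon, ortho to a large group and meta to a chloro group: phenyl in place of bromo on an aromatic carbon. For the measured compounds named here, no measured step covers this change. The expectation in this assay is therefore no step beyond the scatter and no firm direction, resting only on compound 2 at 5 uM. The step expected is a number no lower from compound 1 to compound 3 (the limit leaves the size open). A second limit reading would not be surprising. For compound 3 the estimated value is 5 uM, with an expected range of 2.5 uM to 12 uM.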

Compound 3, half-maximal toxic concentration: 20 uM
For compound 3 the middle estimate is 4.0-fold (0.60 log units) below the measured one, outside the stated range (above it).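

In this assay, phenyl in place of bromo on an aromatic carbon, ortho to a large group and meta to a chloro group, gives an at least 4.0-fold higher number from compound 1 to compound 3 (0.60 log units; beyond the scatter). Among the compounds shown here, this is the first reading to show that a change at this position can move the number beyond the scatter, and the direction is towards more compound tolerated. Compound 1 stands at a limit and not at a number, so the true size of the step stays open: the limit of < 5 uM in this assay, at which 1 of the 3 values shown sits.

With a single replacement at this position, the effect of adding the phenyl ring cannot be separated from that of losing bromo. Going by these compounds, how a methoxy group, an amine or a carboxylic acid at the same position would read in this assay remains open.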